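Replacing a thiazole by piperidine on a bombesin receptor agonist

The compounds below may be only part of what the source reports. "The series", "measured", "known", "first", "only" and "open" are said of these compounds alone.

Measured compounds:
- compound 1 `CCC(C)(C)Cc1c[nH]c(CCc2ccc(-c3cccc(C)n3)cc2)n1`: 106 nM
- compound 2 `CCC(C)(C)Cc1c[nH]c(CCc2ccc(-c3ccncc3)cc2)n1`: 103 nM
- compound 3 `CCC(C)(C)Cc1c[nH]c(CCc2ccc(-c3cnsc3)cc2)n1`: 119 nM

All three compounds share one core and differ only in the ring attached to the benzene. In a functional assay on HEK293 cells for agonist activity at Bombesin receptor subtype-3 (Mus musculus), read by luminescence and calcium flux, with a stated time of 10 min (on this read-out lower numbers stand for an effect already at smaller amounts and higher numbers for an effect only at larger amounts of compound), compound 3 gives 119 nM, the highest of the three numbers, but every step to it lies within the scatter: a 1.1-fold higher number from compound 1 to compound 3 (0.05 log units; within the scatter) and a 1.2-fold higher number from compound 2 to compound 3 (0.06 log units; within the scatter), while a 1.0-fold lower number from compound 1 to compound 2 (0.01 log units; within the scatter). So the three aromatic rings tried here behave alike in this assay.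

Compound 4 `CCC(C)(C)Cc1c[nH]c(CCc2ccc(N3CCCCC3)cc2)n1` has not been measured. The change is piperidin-1-yl in place of 1,2-thiazol-4-yl on an aromatic carbon. Within the data shown here, none of the measured steps covers a saturated, nitrogen-linked ring in this position; they only show that swapping one small aromatic ring for another leaves the number essentially unchanged. A modest move toward a higher number therefore seems the most cautious expectation, with a wide range: the expected step is a 1.3-fold higher number from compound 3 to compound 4 (0.13 log units; within the scatter). For compound 4 the estimate in this assay is 160 nM, expected to fall between 50 nM and 500 nM.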

Compound 4, half-maximal effective concentration: 133 nM
Beside the measured number, compound 4's estimate is 1.2-fold (0.08 log units) above it; the range from low to high includes it.
By their numbers in this assay, from the lowest: compounds 2, 1, 3 and 4 (each within the scatter of the next).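

The earlier compounds shown here carried only aromatic rings at this place, on an aromatic carbon para to a large group, whereas compound 4 has piperidin-1-yl, a six-membered non-aromatic ring. The swap for 1,2-thiazol-4-yl gives a 1.1-fold higher number from compound 3 to compound 4 (0.05 log units; within the scatter) in this assay and stays small, and the comparisons with the two pyridine-bearing compounds, a 1.3-fold higher number from compound 2 to compound 4 (0.11 log units; within the scatter) and a 1.3-fold higher number from compound 1 to compound 4 (0.10 log units; within the scatter), are also within the scatter. Among these four compounds, then, an aromatic ring at this place is not required for a number of this size, although nothing shown explains this tolerance.

As far as these compounds go, it remains open whether a carboxylic acid or a primary amine on the piperidine ring would move the number beyond the scatter. The same question applies to a longer chain, such as n-hexyl, in place of the ring.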